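Swapping Pentyl for Propylsulfonyl on a Weak Inhibitor

The source may hold more compounds than are shown below. What is called first, only, known or untested is meant among the compounds shown, and "the series" means these compounds.

Compound 1, `OCc1ccc(-c2nn(Cc3ccccc3F)c3cccnc23)o1`: 20400 nM
Compound 2, `Cc1nc(-c2nn(Cc3ccccc3F)c3ncccc23)oc1CO`: 900 nM
Compound 3, `CCCCCc1cnc(-c2nn(Cc3ccccc3F)c3ncccc23)nc1N`: 200000 nM

These three numbers come from a functional assay (aorta) with Oryctolagus cuniculus as the target; a higher number here means a weaker inhibitor, a lower number a stronger inhibitor. Compound 3 carries the highest number of the three and is therefore the weakest inhibitor here; compound 1 sits nearest to it, and compound 2 lies furthest away. Compound 4, `CCCS(=O)(=O)c1cnc(-c2nn(Cc3ccccc3F)c3ncccc23)nc1N`, differs from compound 3 in a single place: propylsulfonyl in place of pentyl on an aromatic carbon. Among the compounds with values here, no pair of measured compounds differs in just this way, so the size of this step has no precedent in the data. Compound 4 is expected to show a modest drop in the number, a 3.3-fold lower number from compound 3 to compound 4 (0.52 log units; beyond the scatter), with wide uncertainty in either direction. The estimate for compound 4 in this assay is 60000 nM, within a range from 8000 nM to 300000 nM.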

Compound 4, half-maximal inhibitory concentration: 378000 nM
The estimate for compound 4 lay 6.3-fold (0.80 log units) below the measured number, and the stated range ends below it.
By their numbers in this assay, from the lowest: compound 2; then compound 1; then compounds 3 and 4 (each within the scatter of the next).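

In this assay, putting propylsulfonyl in place of pentyl on this aromatic carbon gives a 1.9-fold higher number from compound 3 to compound 4 (0.28 log units; within the scatter) and so no real difference between the two compounds. At this position, a group with two hydrogen-bond acceptors and a chain with none therefore give numbers that cannot be told apart. Nothing measured here offers an explanation for this result.

Still open, going by these compounds, is whether any group on this carbon can move the number beyond the scatter. A carboxylic acid, a morpholine ring or a simple methyl could each test this.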